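The source may report more compounds than this note shows. Statements on the series, on what has been measured and on what is new or still open speak of the compounds shown alone.

Measured compounds:
compound 1 `COc1ccc(C(=O)Nc2ncc(Cc3cccc(C(F)(F)F)c3)s2)cc1` — an assay on microsomes for inhibition of acyl-CoA desaturase 1 (Mus musculus), with a stated time of 60 min; a higher number here means a weaker inhibitor, a lower number a stronger inhibitor: "not determined" (no result reported)
compound 2 `COc1ccc(C(=O)Nc2ncc(Cc3cccc(F)c3)s2)cc1OCCO` — this assay: 2 nM

Compound 1 stands nowhere on the numbers: in this assay compound 1 has no single number. Compound 2 in this assay gives 2 nM and is the only measured anchor in the series.

Compound 3 `COc1ccc(C(=O)Nc2ncc(Cc3cccc(C(F)(F)F)c3)s2)cc1OCC(C)O` differs from compound 1 by 2-hydroxypropoxy in place of hydrogen on an aromatic carbon. With no number for compound 1, the step cannot be sized or given a direction in this assay. Compound 3 carries the same kind of hydroxy-bearing alkoxy chain that compound 2 carries, and compound 2 gives 2 nM. For compound 3 a half-maximal inhibitory concentration of 4 nM is expected, within a range of 1 nM to 20 nM.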

Compound 3, half-maximal inhibitory concentration: 2170 nM
The estimate for compound 3 lay 540-fold (2.73 log units) below the measured number, outside the stated range (above it).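

Within the data shown here, compound 1 has no single number in this assay and no step to compound 3 can be read. The compounds shown leave open how the 2-hydroxypropoxy group shifts potency on this scaffold. No independent data bear on the result.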